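The compounds below may be only part of what the source reports. "The series", "measured", "known", "first", "only" and "open" are said of these compounds alone.

Working notes on the series. All three measured compounds share one core; they differ in the group carried on the ether oxygen. Compound 1 `COc1ccc2nc(C)cc(OC(C)(C)C(=O)Nc3cc(C)cc(C)c3)c2c1` gives 20000 nM in a physicochemical assay for solubility, in phosphate buffer, measured as kinetic solubility, with a stated time of 1 h, at pH 7.4; on this read-out lower numbers stand for lower solubility and higher numbers for higher solubility. Compound 2 `COc1ccc2nc(C)cc(OCc3ccc4ccccc4n3)c2c1` gives 21000 nM in this assay. Compound 3 `COc1cccc(NC(=O)COc2cc(C)nc3ccc(OC)cc23)c1` gives 35000 nM in this assay. Compound 3 thus carries the largest of the three numbers, but the gaps to compound 2 and to compound 1 both fall within the scatter, so the three measurements cannot be told apart.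

The next compound, compound 4 `COc1ccc2nc(C)cc(OCC(=O)NC3CONC3=O)c2c1`, is not yet measured. Its difference from compound 3 is a group of 6 heavy atoms (3 carbon, 1 nitrogen, 2 oxygen; one five-membered non-aromatic ring with 2 hetero atoms) in place of a group of 8 heavy atoms (7 carbon, 1 oxygen; one six-membered aromatic ring of carbon only), on an amide-type nitrogen. Within the data shown here, no measured pair in the set carries this kind of exchange, so the size of the step must be estimated rather than read off.

The expectation is that the step from compound 3 to compound 4 in this assay is upward and beyond the scatter, a 2.3-fold higher number from compound 3 to compound 4 (0.36 log units; beyond the scatter) being the estimated change. For compound 4 the estimated value in this assay is 80000 nM, with a range from 30000 nM to 200000 nM; the anchor is compound 3 because it gives 35000 nM. The measurement will settle whether the exchange moves the number at all.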

Compound 4, solubility: >= 166000 nM
Compound 4: no number, only a limit (the forecaster's own chance of this, stated with the estimate: 15%); middle value at least 2.0-fold (0.31 log units) from the limit.
By their numbers in this assay, from the lowest: compounds 1, 2 and 3 (each within the scatter of the next). At a limit, above all of these: compound 4.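

Up to this point the three measured compounds could not be told apart in this assay, so nothing showed whether the group on the ether oxygen could move this read-out at all. Among these compounds, the exchange of 3-methoxyphenyl for the five-membered non-aromatic ring with 2 hetero atoms, on the amide-type nitrogen, gives an at least 4.7-fold higher number from compound 3 to compound 4 (0.67 log units; beyond the scatter), the first step that lies beyond the scatter and the first sign that this position can register a change. For compound 4 the read-out is a limit of the assay and not a number: the limit of >= 166000 nM in this assay, at which 1 of the 4 values shown sits.

Among the compounds shown here, the step therefore has a floor but no known size, and the single pair cannot separate what the departure of the 3-methoxyphenyl contributes from what the entering ring contributes. A short alkyl chain or an open-chain amine on the same amide-type nitrogen would bear on that question, and any further compound that reaches the same limit could not be ranked against compound 4 in this assay.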